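Capping One Phenol of a Stilbene Diol with Methyl

The source may report more compounds than this note shows. Statements on the series, on what has been measured and on what is new or still open speak of the compounds shown alone.

Measured so far:
Compound 1 `Oc1ccccc1/C=C/c1ccccc1O`: 23 ug/mL
Compound 2 `Oc1cccc(/C=C/c2ccccc2O)c1`: 20.1 ug/mL
Compound 3 `Oc1cccc(/C=C/c2cccc(O)c2)c1`: 21 ug/mL

All three values come from a functional assay on MCF7 cells (Homo sapiens) for inhibition, read by MTT assay, with a stated time of 2 days; a higher number here means a weaker inhibitor, a lower number a stronger inhibitor. Compound 1, compound 2 and compound 3 lie within the scatter of one another, so compound 1 is not separated from either of its two neighbours on the numbers shown. Compound 4 `COc1ccccc1/C=C/c1ccccc1O` has not yet been measured in this assay. It differs from compound 1 by methyl in place of hydrogen on an oxygen on an aromatic ring, so one of the two hydroxy groups becomes a methoxy group while the shared core stays the same. Going by the values given here, no measured pair shows this change, so the size of its step is unknown. The step of a 1.3-fold higher number from compound 1 to compound 4 (0.12 log units; within the scatter) is expected to be small, if anything a weakening, and may not exceed the scatter. Compound 4 is therefore estimated at 30 ug/mL, with a range from 12 ug/mL to 75 ug/mL.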

Compound 4, half-maximal inhibitory concentration: 17.9 ug/mL
Beside the measured number, compound 4's estimate is 1.7-fold (0.22 log units) above it; low and high end bracket the measured number.
By their numbers in this assay, from the lowest: compounds 4, 2, 3 and 1 (each within the scatter of the next).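

In this assay, putting methyl on this oxygen, which turns one hydroxy group into a methoxy group, gives a 1.3-fold lower number from compound 1 to compound 4 (0.11 log units; within the scatter). Going by these compounds alone, this is the first measured view of this change, and it shows that the hydrogen on this oxygen can be replaced without a step that rises above the scatter. Nothing available here offers an explanation for this result.

Still open, as far as these compounds go, is whether a longer chain on this oxygen, or an amine or a carboxylic acid in place of the hydroxy group, would give a step beyond the scatter. Also open, from the compounds shown here alone, is what methyl on the second hydroxy group would do.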